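The source may hold more compounds than are shown below. What is called first, only, known or untested is meant among the compounds shown, and "the series" means these compounds.

Compound 3 `Cc1ccc2ncc(S(=O)(=O)c3cccc(C#N)c3)c(N3CCC(C)CC3)c2c1` carries a 3-cyanophenyl on its sulfonyl sulfur. For the measured compounds named here, in an assay on isolated protein for displacement of a labelled ligand from metabotropic glutamate receptor 5 (Homo sapiens), with a stated time of 60 min, tested at 1 uM (on this read-out higher numbers stand for more inhibition at the one concentration tested (going by the name of the read-out) and lower numbers for less inhibition), compound 3 gives 52%, the lowest of the three numbers so far. Compound 1 `Cc1ccc(S(=O)(=O)c2cnc3ccc(F)cc3c2N2CCC(C)CC2)cc1C` gives 92% in this assay. Compound 2 `Cc1ccc2ncc(S(=O)(=O)c3ccc(Cl)c(Cl)c3)c(N3CCC(C)CC3)c2c1` differs from compound 3 only at the sulfonyl substituent; in this assay compound 2 gives 82%. Going by the values given here, the one step that touches this position, from the 3,4-dichlorophenyl of compound 2 to the 3-cyanophenyl of compound 3, is a number 30 percentage points lower from compound 2 to compound 3 (beyond the scatter).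

Compound 4 `Cc1ccc2ncc(S(=O)(=O)c3ccc(C)c(C)c3)c(N3CCC(C)CC3)c2c1` is obtained from compound 3 by the change (3,4-dimethylphenyl in place of 3-cyanophenyl on a sulfonyl sulfur). Among the compounds with values here, compound 4 thus returns to a phenyl bearing two groups at the 3- and 4-positions, as compound 2 does, and this resemblance is the only guide available. Because the step of a number 30 percentage points lower from compound 2 to compound 3 (beyond the scatter) was a clear loss on going to the 3-cyanophenyl, compound 4 is expected to recover a good part of it. The estimated step for compound 4 is a number 26 percentage points higher from compound 3 to compound 4 (beyond the scatter), giving an expected value for compound 4 of 78%, with a likely range from 58% to 94%.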

Compound 4, a percentage reported as inhibition, at one concentration (the size of the read-out at that concentration, not a potency): 90%
The estimate for compound 4 lay 12 percentage points below the measured number; measured number inside the range.
By their numbers in this assay, from the lowest: compound 3; then compounds 2, 4 and 1 (each within the scatter of the next).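

On the sulfonyl sulfur, the 3,4-dimethylphenyl gives a number 38 percentage points higher from compound 3 to compound 4 (beyond the scatter) in this assay and so shows that the low number of compound 3 does not extend to every group at this place. The two phenyls bearing a pair of groups cannot be told apart, with a number 8 percentage points higher from compound 2 to compound 4 (within the scatter) for 3,4-dimethylphenyl in place of 3,4-dichlorophenyl. On an aromatic carbon of the core, methyl in place of fluoro also leaves the two compounds indistinguishable, with a number 2 percentage points lower from compound 1 to compound 4 (within the scatter) for that change.

On these data alone, it remains open whether a phenyl carrying a single methyl or chloro, or a methoxy or trifluoromethyl group on this phenyl, would stay with compound 4 or fall towards compound 3. Nothing given here accounts for the drop seen with the 3-cyanophenyl.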